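Swapping Methyl for Nitro on the Pendant Aryl Ring

The source may report more compounds than this note shows. Statements on the series, on what has been measured and on what is new or still open speak of the compounds shown alone.

Measured so far in an ADME assay on NIH3T3 cells (Mus musculus) for cytotoxicity, read by MTT assay, with a stated time of 24 h; on this read-out higher numbers stand for weaker inhibition and lower numbers for stronger inhibition:
- compound 1, `Cc1ccc(-c2cs/c(=N/NC(=O)CSc3nnnn3-c3ccccc3)n2-c2ccccc2)cc1`: > 500 ug/mL
- compound 2, `O=C(CSc1ncccn1)N/N=c1/scc(-c2ccc([N+](=O)[O-])cc2)n1-c1ccccc1`: 193 ug/mL
- compound 3, `Cc1ccc(-c2cs/c(=N/NC(=O)CSc3nnnn3C)n2-c2ccccc2)cc1`: 243 ug/mL

The value for compound 1 is a limit of this assay, not a number. Compound 3 gives the highest of the two numbers reported, and compound 2 sits within the scatter of it. Among the compounds with values here, the one step measured on this set, an at least 2.0-fold lower number from compound 1 to compound 3 (0.31 log units; beyond the scatter), concerns the group on the aromatic nitrogen of the tetrazole, and it stands out because one end of it is the limit of > 500 ug/mL in this assay, at which 1 of the 3 values shown sits.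

Compound 4, `Cn1nnnc1SCC(=O)N/N=c1/scc(-c2ccc([N+](=O)[O-])cc2)n1-c1ccccc1`, has not been measured yet. It differs from compound 3 by nitro in place of methyl on an aromatic carbon. Within the data shown here, no measured step covers this change; compound 2 carries the same nitrophenyl ring but also a different heteroaryl sulfide, so its value and that of compound 4 cannot be compared as a single step. The expectation for compound 4 is therefore a number close to that of compound 3, with the step of a 1.2-fold lower number from compound 3 to compound 4 (0.06 log units; within the scatter) expected to stay within the scatter. Compound 4 is estimated at 210 ug/mL, in the range 100 ug/mL to 450 ug/mL.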

Compound 4, half-maximal inhibitory concentration: 167 ug/mL
Estimate against measurement, compound 4: 1.3-fold (0.10 log units) above; low and high end bracket the measured number.
By their numbers in this assay, from the lowest: compounds 4, 2 and 3 (each within the scatter of the next). At a limit, above all of these: compound 1.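

In this assay, the exchange of 4-methylphenyl for 4-nitrophenyl now has a measured step of its own (a 1.5-fold lower number from compound 3 to compound 4 (0.16 log units; within the scatter)), so on this pair nitro in place of methyl moves the number by no more than the scatter. The sulfur substituent can now also be read with the nitrophenyl ring held fixed (a 1.2-fold lower number from compound 2 to compound 4 (0.06 log units; within the scatter)), and 1-methyl-1H-tetrazol-5-yl and pyrimidin-2-yl cannot be told apart on this read-out. Nothing at hand gives a reason for either result.

The compounds shown leave open how an amine or a carboxylic acid at this place on the ring would read. They also leave open where a longer chain on the aromatic nitrogen of the tetrazole would fall, since compound 1, with phenyl there, gives only a limit of the assay, > 500 ug/mL.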